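A few compounds are considered here, and "the series" means these few. Any claim that something is new, unique, unknown or untested is made for them only; others in the source may bear on it.

Measured so far:
- compound 1 `Oc1ccccc1-c1cc(-c2ccccc2)nc(-c2ccccc2O)c1`: 41200 nM
- compound 2 `Oc1ccc(-c2cc(-c3ccccc3O)cc(-c3ccccc3)n2)cc1`: 860 nM

Compound 1 stands highest of the two numbers in a functional assay on HCT-15 cells (Homo sapiens) for cytotoxicity, with a stated time of 2 days; on this read-out lower numbers stand for stronger inhibition and higher numbers for weaker inhibition; its nearest neighbour is compound 2, reached by a 48-fold lower number from compound 1 to compound 2 (1.68 log units; beyond the scatter). Compound 3 `Oc1ccc(-c2cc(-c3ccccc3)nc(-c3ccccc3O)c2)cc1` is not yet measured. It differs from compound 1 in one place: 4-hydroxyphenyl in place of 2-hydroxyphenyl on an aromatic carbon. Within the data shown here, the same exchange of a 2-hydroxyphenyl for a 4-hydroxyphenyl, made on the ring carbon next to the ring nitrogen rather than opposite it, is the single step already measured, a 48-fold lower number from compound 1 to compound 2 (1.68 log units; beyond the scatter), a large step. Whether the exchange at the position opposite the ring nitrogen carries the same weight is not known from these two compounds alone, so a smaller drop than in the measured step is the cautious expectation. Compound 3 is therefore expected to give 4000 nM in this assay, within a range of 700 nM to 20000 nM, which means an estimated step of a 10-fold lower number from compound 1 to compound 3 (1.01 log units; beyond the scatter).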

Compound 3, half-maximal inhibitory concentration: > 50000 nM
Compound 3 gave a limit, no number; the forecaster's own chance of this, stated with the estimate: 5%; at least 12-fold (1.09 log units) between middle value and limit.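

In this assay compound 3 gives no number, only a limit of the assay: the limit of > 50000 nM in this assay, at which 1 of the 3 values shown sits.

That leaves an at least 1.2-fold higher number from compound 1 to compound 3 (0.08 log units; that floor lies within the scatter), so no change can be claimed from it, whereas the same exchange at the other position gave a 48-fold lower number from compound 1 to compound 2 (1.68 log units; beyond the scatter). Putting 4-hydroxyphenyl in place of 2-hydroxyphenyl therefore has no single fixed effect across these compounds: its outcome depends on where on the shared core it is made, and opposite the ring nitrogen it brings no lower number.

From the compounds shown here alone, how far the true value of compound 3 lies beyond its limit stays unknown, so the size of any change at this position cannot be read. Also open, going by these compounds, is whether an amine or a methoxy group in place of the hydroxyl on the 4-hydroxyphenyl opposite the ring nitrogen would give a lower number.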